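The source may hold more compounds than are shown below. What is called first, only, known or untested is meant among the compounds shown, and "the series" means these compounds.

In a functional assay on U-937 cells (Homo sapiens) for inhibition, read by MTT assay, with a stated time of 72 h (on this read-out higher numbers stand for weaker inhibition and lower numbers for stronger inhibition), compound 3 (`O=C(NO)c1ccc(CNCc2nc(-c3ccccc3)no2)cc1`) gives 7210 nM and compound 2 (`Nc1ccccc1NC(=O)c1ccc(CNCc2nc(-c3cccs3)no2)cc1`) gives 5960 nM, two numbers that lie within the scatter of each other, so neither can be ranked above the other. Compound 1 (`Nc1ccccc1NC(=O)c1ccc(CNCc2nc(-c3ccc(Cl)cc3)no2)cc1`) gives 430 nM, well below both.

Compound 4 (`O=C(NO)c1ccc(CNCc2nc(-c3ccc([N+](=O)[O-])cc3)no2)cc1`) has not yet been measured. It is compound 3 with nitro in place of hydrogen on an aromatic carbon, para to a large group, so that phenyl becomes 4-nitrophenyl: nitro in place of hydrogen on an aromatic carbon.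

Among the measured compounds shown here, only one measured step touches this end of the molecule: a 14-fold higher number from compound 1 to compound 2 (1.14 log units; beyond the scatter), a large change on swapping 4-chlorophenyl for thiophen-2-yl. That shows the group at this end can matter. For the measured compounds named here, it is only a loose guide, however, since compound 1 and compound 2 carry a different group at the other end from compound 3, and no measured pair swaps hydrogen for nitro. Going by the values given here, the single low number of compound 1, at 430 nM, does come from a ring substituted in the same place, which hints weakly at a lower number.

A modest step towards stronger inhibition is therefore expected in this assay, estimated as a 2.1-fold lower number from compound 3 to compound 4 (0.31 log units; beyond the scatter), and it may not clear the scatter. For compound 4 the estimated value is 3500 nM, with an expected range from 900 nM to 11000 nM.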

Compound 4, half-maximal inhibitory concentration: 6520 nM
Beside the measured number, compound 4's estimate is 1.9-fold (0.27 log units) below it, within the range that was stated.
By their numbers in this assay, from the lowest: compound 1; then compounds 2, 4 and 3 (each within the scatter of the next).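

In this assay, nitro in place of hydrogen on an aromatic carbon, para to a large group, gives a 1.1-fold lower number from compound 3 to compound 4 (0.04 log units; within the scatter), so the numbers of the two compounds cannot be told apart. This is the first pair shown that compares a bare phenyl with a substituted one while all else stays the same, and on the core of compound 3 the 4-nitrophenyl group brings no readable shift. The large step of a 14-fold higher number from compound 1 to compound 2 (1.14 log units; beyond the scatter) therefore does not extend to this change, as it swaps one whole ring group for another on a different core, and no measurement shown here offers any explanation for the flat result.

Still open, from the compounds shown here alone, is whether an amine or a methoxy group in the same place would give a number that stands apart from that of compound 3 on this core. Also open is what lies behind the low number of compound 1, which gives 430 nM, since it differs from compound 3 at both ends and no pair shown separates the 4-chlorophenyl group from the group at the other end.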